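Mirror-image partner of compound 3 awaits its measurement

The compounds below may be only part of what the source reports. "The series", "measured", "known", "first", "only" and "open" are said of these compounds alone.

Measured in a functional assay (plasma) for inhibition, with Mus musculus as the target; on this read-out lower numbers stand for stronger inhibition and higher numbers for weaker inhibition:
- Compound 1 `CO[C@]1(c2cc(F)cc(OCc3ccc4c(ccc(=O)n4C)c3)c2)CCO[C@H](C)C1`: 8 nM
- Compound 2 `CO[C@@]1(c2cc(F)cc(OCc3ccc4c(ccc(=O)n4C)c3)c2)CCO[C@@H](C)C1`: 60 nM
- Compound 3 `CO[C@@]1(c2cc(F)cc(OCc3ccc4c(ccc(=O)n4C)c3)c2)CCO[C@H](C)C1`: 9 nM

Compound 3 lies within the scatter of compound 1 and well below compound 2. The next compound is compound 4 `CO[C@]1(c2cc(F)cc(OCc3ccc4c(ccc(=O)n4C)c3)c2)CCO[C@@H](C)C1`, and the change to it is the two compounds have the same atoms and bonds and differ only in configuration as drawn: 2 of 2 stereo elements differ (all stereocentres are inverted: mirror images); a stereocentre at a saturated ring carbon is drawn S in compound 3 and R in compound 4; a stereocentre at a saturated ring carbon is drawn R in compound 3 and S in compound 4. Only configuration separates the measured compounds, so all three measured steps bear on it. Within the data shown here, the one mirror-image pair already measured shows a 7.5-fold higher number from compound 1 to compound 2 (0.88 log units; beyond the scatter). Two single inversions split that effect. One centre hardly matters, with a 1.1-fold higher number from compound 1 to compound 3 (0.05 log units; within the scatter). The other carries nearly all of it, with a 6.7-fold lower number from compound 2 to compound 3 (0.82 log units; beyond the scatter). Going to compound 4 inverts both centres, so the second step should run in reverse, while the first should add little. A modest rise in this assay is therefore expected, of about the size seen between the mirror-image compounds 1 and 2. The expected change is a 5.6-fold higher number from compound 3 to compound 4 (0.74 log units; beyond the scatter). Compound 4 is estimated at 50 nM, with an expected range from 15 nM to 150 nM.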

Compound 4, half-maximal inhibitory concentration: 0.4 nM
Estimate against measurement, compound 4: 130-fold (2.10 log units) above; the measured number lies below the stated range.
By their numbers in this assay, from the lowest: compound 4; then compounds 1 and 3 (each within the scatter of the next); then compound 2.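

In this assay the two stereocentres do not act independently: the centre that separates compounds 1 and 3, where the values lie within the scatter, also separates the other pair and there gives a 150-fold lower number from compound 2 to compound 4 (2.18 log units; beyond the scatter). The second centre behaves the same way, since a 20-fold lower number from compound 1 to compound 4 (1.30 log units; beyond the scatter) is a drop in the number, as is a 6.7-fold lower number from compound 2 to compound 3 (0.82 log units; beyond the scatter), although that centre is inverted in the opposite sense in the two steps, R to S in the first and S to R in the second. The mirror-image change therefore depends on the starting compound, with a 23-fold lower number from compound 3 to compound 4 (1.35 log units; beyond the scatter), and compound 4, whose steps to all the others lie beyond the scatter, is the strongest inhibitor of the four.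

As far as these compounds go, what remains open is whether this dependence on configuration persists when the methoxy group gives way to a hydroxyl group or the methyl group to an ethyl group. The compounds shown also leave open how the four stereoisomers rank on any other read-out.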